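This account rests on a few compounds, and the source may have more. Where it says the series, first, only, none or still open, it means among the compounds named here.

In a functional assay (aorta) with Rattus norvegicus as the target (on this read-out lower numbers stand for stronger inhibition and higher numbers for weaker inhibition), compound 2 `CC1(C)Oc2ccc(C#N)cc2[C@@H](/N=C(\NC#N)Sc2ccccc2)[C@@H]1O` gives 4900 nM. Compound 3 `CC1(C)Oc2ccc(C#N)cc2[C@@H](NC(=O)NCc2ccccc2)[C@@H]1O` gives 5600 nM, which lies within the usual scatter of the value for compound 2. Compound 1 `CC1(C)Oc2ccc(C#N)cc2[C@@H](/N=C(\NC#N)Oc2ccccc2)[C@@H]1O` reads > 100000 nM, which is a limit of the assay and not a number.

Compound 4 `CC1(C)Oc2ccc(C#N)cc2[C@@H](/N=C(\NC#N)Nc2ccc(N)cc2)[C@@H]1O` carries (4-aminophenyl)amino in place of phenylsulfanyl on a carbon with a double bond to nitrogen.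

Among the compounds with values here, only one measured step bears on this place: an at least 20-fold lower number from compound 1 to compound 2 (1.30 log units; beyond the scatter). That large step shows that a swap here can move the number strongly, although it involves a different swap, so a moderately higher number is expected, with wide uncertainty. The estimated step is a 2.0-fold higher number from compound 2 to compound 4 (0.31 log units; beyond the scatter). For compound 4 the expected value is 10000 nM, with an estimated range from 2000 nM to 60000 nM.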

Compound 4, half-maximal inhibitory concentration: 3500 nM
Compound 4: the middle estimate sits 2.9-fold (0.46 log units) above what was measured; measured number inside the range.
By their numbers in this assay, from the lowest: compounds 4, 2 and 3 (each within the scatter of the next). At a limit, above all of these: compound 1.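

Within the data shown here, at this place on a carbon with a double bond to nitrogen, a change of a 1.4-fold lower number from compound 2 to compound 4 (0.15 log units; within the scatter) shows that phenylsulfanyl is not the only group that gives a number in this range: (4-aminophenyl)amino does so too. Among these compounds, a change of an at least 28-fold lower number from compound 1 to compound 4 (1.45 log units; beyond the scatter) leaves phenoxy as the one group apart from the other two. Compound 1 stands at a limit, so this second step gives only a minimum size: the limit of > 100000 nM in this assay, at which 1 of the 4 values shown sits.

Going by these compounds, whether the amino group on the ring matters stays open. Plain phenylamino would test that, while a carboxylic acid on the ring or a small methylamino group would show how much change this place accepts.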